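The source may hold more compounds than are shown below. What is called first, only, known or untested is meant among the compounds shown, and "the series" means these compounds.

In an assay on cells for inhibition of HSP60/HSP10 (Homo sapiens), with a stated time of 60 min (a higher number here means a weaker inhibitor, a lower number a stronger inhibitor), compound 1 `O=S(=O)(Nc1ccc(-c2nc3ccccc3o2)cc1)c1ccc(Cl)s1` gives 31000 nM. Compound 2 `O=S(=O)(Nc1ccc(-c2nc3ccccc3o2)cc1)c1ccccc1F` reaches only the limit of this assay, > 100000 nM, so its position is known only as a bound. Among the compounds with values here, the one measured step, an at least 3.2-fold higher number from compound 1 to compound 2 (0.50 log units; beyond the scatter), is therefore itself a bound, and it rests on (the limit of > 100000 nM in this assay, at which 1 of the 2 values shown sits). Compound 3 `C=Cc1ccc(S(=O)(=O)Nc2ccc(-c3nc4ccccc4o3)cc2)cc1` differs from compound 2 in a single place: 4-vinylphenyl in place of 2-fluorophenyl on a sulfonyl sulfur. Within the data shown here, no measured step concerns a 4-vinylphenyl group, and the only step available, an at least 3.2-fold higher number from compound 1 to compound 2 (0.50 log units; beyond the scatter), shows that exchanging the group on the sulfonyl sulfur can move this assay by a modest amount or more. Since compound 2 stands at a limit, any change from it toward a stronger inhibitor would appear as a step into the measurable range; the expected step of an at least 1.6-fold lower number from compound 2 to compound 3 (0.22 log units; that floor lies within the scatter) is accordingly uncertain. Compound 3 is estimated at 60000 nM, within 15000 nM to 200000 nM.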

Compound 3, half-maximal inhibitory concentration: > 100000 nM
Compound 3 was reported as a limit; the forecaster's own chance of this, stated with the estimate: 40%; at least 1.6-fold (0.22 log units) between middle value and limit.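

In this assay compound 3 also sits at a limit, > 100000 nM, so the step between compound 2 and compound 3 cannot be read, and the 4-vinylphenyl group adds a second group on the sulfonyl sulfur at that limit: the limit of > 100000 nM in this assay, at which 2 of the 3 values shown sit.

Taking 4-vinylphenyl in place of 5-chlorothiophen-2-yl gives an at least 3.2-fold higher number from compound 1 to compound 3 (0.50 log units; beyond the scatter), a bound of the same size as the one for 2-fluorophenyl, now reached with a different phenyl group. Of the three groups shown at this position, only the 5-chlorothiophen-2-yl group of compound 1 gives a value that is not a limit, 31000 nM.

On these data alone, whether anything separates 2-fluorophenyl from 4-vinylphenyl remains open. So does whether the chlorine or the thiophene ring of compound 1 matters more, and how a plain thiophene or a pyridine on the sulfonyl sulfur would stand.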